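Pyrazole sulfonamides against melanoma cells: a demethylation step

The source may hold more compounds than are shown below. What is called first, only, known or untested is meant among the compounds shown, and "the series" means these compounds.

For the measured compounds named here, compound 1 `COc1ccc(OC)c(-c2cc(-c3ccccc3)nn2-c2ccc(S(N)(=O)=O)cc2)c1` gives in a functional assay on cells (Melanoma cell, Homo sapiens) for cytotoxicity, read by sulforhodamine B assay, with a stated time of 48 h (on this read-out lower numbers stand for stronger inhibition of growth and higher numbers for weaker inhibition of growth), the highest of the two numbers so far, namely 40800 nM. Its nearest neighbour, compound 2 `COc1ccc(OC)c(-c2cc(-c3ccccc3)nn2-c2ccc(S(=O)(=O)NC(C)=O)cc2)c1`, gives 36200 nM, and the step of a 1.1-fold lower number from compound 1 to compound 2 (0.05 log units; within the scatter) stays within the scatter. Compound 3 `NS(=O)(=O)c1ccc(-n2nc(-c3ccccc3)cc2-c2cc(O)ccc2O)cc1` carries 2,5-dihydroxyphenyl in place of 2,5-dimethoxyphenyl on an aromatic carbon. Going by the values given here, no measured step touches this change; the only step known alters the sulfonamide nitrogen instead, so nothing predicts its direction. For compound 3 the expected value is 22000 nM, with a range from 5000 nM to 80000 nM. The expected step of a 1.9-fold lower number from compound 1 to compound 3 (0.27 log units; within the scatter) is estimated as modest and may well lie within the scatter.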

Compound 3, concentration for total growth inhibition: 92000 nM
Compound 3: middle estimate off by 4.2-fold (0.62 log units), on the low side, outside the stated range (above it).
By their numbers in this assay, from the lowest: compounds 2 and 1 (each within the scatter of the next); then compound 3.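

At this position of the shared core, 2,5-dihydroxyphenyl in place of 2,5-dimethoxyphenyl gives a 2.3-fold higher number from compound 1 to compound 3 (0.35 log units; beyond the scatter) in this assay and so moves toward weaker inhibition of growth. For the compounds shown here, this is the first step beyond the scatter, whereas the change on the sulfonamide nitrogen stayed within it. No measurement on hand gives a reason for this shift.

On these data alone, it remains open whether one oxygen alone accounts for the step, as a 2-hydroxy-5-methoxyphenyl group would show. Also open, as far as these compounds go, is how an aminophenyl or a carboxyphenyl group would read at this position.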